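This account rests on a few compounds, and the source may have more. Where it says the series, first, only, none or still open, it means among the compounds named here.

Of the compounds shown here, two have so far been measured in an assay on isolated protein for inhibition of aldehyde dehydrogenase 1A1 (Homo sapiens), read by spectrophotometry, tested at 10 uM; a higher number here means more inhibition at the concentration tested (going by the name of the read-out), a lower number less inhibition. Compound 1 `Cc1cccc(Cn2c(CN3CCN(C(=O)C4CCCC4)CC3)nc3ccccc32)c1` gives 67.5% in this assay, and compound 2 `Cc1cccc(Cn2c(OC3CCN(C(=O)C4CC4)CC3)nc3ccccc32)c1` gives 80.6%. Compound 1 thus stands lowest of the two numbers, and the gap to compound 2, its nearest neighbour, lies beyond the usual scatter of this assay. The two compounds differ in more than one place, so nothing beyond what the two values show can be said of any single part of that difference.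

Compound 3 `Cc1cccc(Cn2c(CN3CCN(C(=O)C4CCC4)CC3)nc3ccccc32)c1` has not yet been measured. It differs from compound 1 in one place: cyclobutyl in place of cyclopentyl on a carbonyl carbon. Among the compounds with values here, no measured pair carries this change, so its size cannot be read off and can only be expected. The change is small and keeps donors, acceptors and charge unchanged, so the step of a number 2.5 percentage points lower from compound 1 to compound 3 (within the scatter) is expected to stay within the scatter, with no clear direction. For compound 3 the estimate in this assay is 65%, with a range from 50% to 80%.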

Compound 3, a percentage reported as inhibition, at one concentration (the size of the read-out at that concentration, not a potency): 69.1%
Estimate against measurement, compound 3: 4.1 percentage points below; the range from low to high includes it.
By their numbers in this assay, from the lowest: compounds 1 and 3 (each within the scatter of the next); then compound 2.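

Cyclobutyl in place of cyclopentyl on a carbonyl carbon, whose other neighbours are an amide-type nitrogen in a ring, gives the first step in the series that can be read at a single place: in this assay it is a number 1.6 percentage points higher from compound 1 to compound 3 (within the scatter). At this position, then, the five-membered and the four-membered carbon rings cannot be told apart by this read-out at the concentration tested, which the earlier pair, differing in more than one place, could not show. Within the data shown here, nothing measured so far offers an explanation for this result.

Among these compounds, this single step says only that these two ring sizes give matching numbers, so it remains open how much change the position accepts when the group on the carbonyl carbon is no longer a small carbon ring, for example a phenyl ring, a tert-butyl group or a ring carrying an amine. Among the compounds shown here, also open is whether the same exchange gives a step of similar size on the core of compound 2, where no such one-place pair stands yet.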